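The source may report more compounds than this note shows. Statements on the series, on what has been measured and on what is new or still open speak of the compounds shown alone.

Compound 1, whose structure is `Cc1ccc(Cn2c(/C=C3\SC(=S)N(CC(=O)O)C3=O)nc3cc(F)ccc32)cc1`, is the starting point. In a functional assay on Raji cells (Homo sapiens) for cytotoxicity, read by MTT assay, with a stated time of 48 h (on this read-out lower numbers stand for stronger inhibition and higher numbers for weaker inhibition), compound 1 gives 3280 nM. Compound 2, with structure `COc1ccc2c(c1)nc(/C=C1\SC(=S)N(CC(=O)O)C1=O)n2Cc1ccc(C)cc1`, shares the core of compound 1 and differs from it in one place: methoxy in place of fluoro on an aromatic carbon. In this assay compound 2 gives 1790 nM, and the change made a 1.8-fold lower number from compound 1 to compound 2 (0.26 log units; within the scatter), so these two compounds cannot be told apart on this read-out.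

Compound 3, with structure `O=C(O)CN1C(=O)/C(=C/c2nc3ccc(F)cc3n2Cc2ccccc2F)SC1=S`, has a different core; the difference between the two cores is not broken down here. In this assay compound 3 gives 22400 nM, the highest of the three numbers measured, and its distance from compound 1 and compound 2 lies beyond the usual scatter.

Compound 4, with structure `COc1ccc2nc(/C=C3\SC(=S)N(CC(=O)O)C3=O)n(Cc3ccccc3F)c2c1`, has not yet been measured. It stands to compound 3 as compound 2 stands to compound 1, with the same change at the same kind of place: methoxy in place of fluoro on an aromatic carbon. For the measured compounds named here, because a 1.8-fold lower number from compound 1 to compound 2 (0.26 log units; within the scatter) was the only time this change was measured and stayed within the scatter, a step of similar size is expected on the other core. The expected step here, a 1.9-fold lower number from compound 3 to compound 4 (0.27 log units; within the scatter), rests on that single earlier example alone. For compound 4 the expected value is 12000 nM, with a likely range from 5000 nM to 30000 nM.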

Compound 4, half-maximal inhibitory concentration: 12400 nM
Compound 4: middle estimate off by 1.0-fold (0.01 log units), on the low side, and the stated range covers the measured number.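

In this assay, putting methoxy in place of fluoro on an aromatic carbon gave a 1.8-fold lower number from compound 3 to compound 4 (0.26 log units; within the scatter), so these two compounds cannot be told apart on this read-out, and the same was true of the first pair. Seen side by side, the change behaves alike on both cores, with two small steps that agree: the same change on two cores in this assay, a 1.8-fold lower number (0.26 log units; within the scatter) from compound 1 to compound 2 and a 1.8-fold lower number (0.26 log units; within the scatter) from compound 3 to compound 4, 1.0-fold (0.01 log units) apart, within the scatter of two such steps This does not show that methoxy truly lowers the number, as each step on its own is small enough to be ordinary scatter; what it supports is the more modest statement that swapping these two groups made no readable difference on either core, and two pairs say nothing about any further core.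

The compounds shown leave open whether a different group on the same aromatic carbon, such as an amine, a chloro group or a longer chain like ethoxy, would give a step beyond the scatter. They also leave open whether the agreement between the two pairs would hold in other cell lines or with other read-outs, as all four numbers come from a single cell-based test.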